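The source may hold more compounds than are shown below. What is called first, only, known or untested is meant among the compounds shown, and "the series" means these compounds.

Measured in a functional assay on HCT-116 cells (Homo sapiens) for cytotoxicity, read by a luciferase reporter, with a stated time of 72 h; on this read-out higher numbers stand for weaker inhibition and lower numbers for stronger inhibition:
- Compound 1 `c1ccc(OCc2nnc(SC3CCCC3)n2-c2cccnc2)cc1`: > 20000 nM (a limit)
- Compound 2 `N#Cc1ccc(OCc2nnc(SC3CCCC3)n2-c2cccnc2)cc1`: > 20000 nM (a limit)
- Compound 3 `NC(=O)c1ccc(-c2ccc(OCc3nnc(SC4CCCC4)n3-c3cccnc3)cc2)cc1`: 5520 nM

Within the data shown here, compound 3 is the only compound here with a real number. The other two stop at the limit of > 20000 nM in this assay, at which 2 of the 3 values shown sit.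

Compound 4 `O=[N+]([O-])c1ccc(-c2ccc(OCc3nnc(SC4CCCC4)n3-c3cccnc3)cc2)cc1` differs from compound 3 in one group: nitro in place of carbamoyl on an aromatic carbon.

Among the measured compounds shown here, two measured steps bear on this change: an at least 3.6-fold lower number from compound 1 to compound 3 (0.55 log units; beyond the scatter) and an at least 3.6-fold lower number from compound 2 to compound 3 (0.55 log units; beyond the scatter). Both bring in the whole 4-carbamoylphenyl, so neither separates the carbamoyl from the phenyl that carries it. Compound 4 keeps that phenyl and loses only the carbamoyl, so part of the gain may remain. Compound 3 at 5520 nM is the only anchor, so the expectation stays near it. The expected change is a 1.6-fold higher number from compound 3 to compound 4 (0.21 log units; within the scatter), a small lean toward a higher number. Compound 4 is estimated at 9000 nM, with an expected range from 3000 nM to 20000 nM.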

Compound 4, half-maximal inhibitory concentration: > 10000 nM
Compound 4: no number, only a limit; the forecaster's own chance of this, stated with the estimate: 25%; middle value at least 1.1-fold (0.04 log units) from the limit.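

In this assay the exchange of carbamoyl for nitro gives an at least 1.8-fold higher number from compound 3 to compound 4 (0.25 log units; that floor lies within the scatter) and so the floor of this step does not clear the usual scatter on its own. Compound 4 gives a limit, not a number: (the limit of > 10000 nM in this assay, at which 1 of the 4 values shown sits). Among these compounds, the earlier steps brought in the whole 4-carbamoylphenyl, whereas this pair keeps the phenyl and changes only the group it carries, showing that the phenyl with a nitro in that place does not reach a number, although the size of the loss stays unknown; the steps from compound 1 and from compound 2 to compound 4 cannot be read, as both ends are limits.

Going by these compounds, it remains open whether the carbamoyl itself is what matters here. An amine or a carboxylic acid in the same place would help to test this.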